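Series notes: propyl to trifluoromethyl on the shared core

A few compounds are considered here, and "the series" means these few. Any claim that something is new, unique, unknown or untested is made for them only; others in the source may bear on it.

Measured so far:
compound 1 `CCCCOC(=O)NS(=O)(=O)c1ccc(CCC)cc1-c1ccc(Cn2c(Cc3ccccc3)nc3ccccc32)cc1`: 15 nM
compound 2 `CCCCOC(=O)NS(=O)(=O)c1ccc(CCC)cc1-c1ccc(Cn2c(CCC)nc3ccccc32)cc1`: 14 nM

In an assay on membranes from HEK293 cells for displacement of a labelled ligand from Type-2 angiotensin II receptor (Homo sapiens), read by radioligand binding (on this read-out lower numbers stand for stronger inhibition and higher numbers for weaker inhibition), compound 2 gives 14 nM, the lower of the two numbers, with compound 1 within the scatter of it, so no order between them is claimed. For the measured compounds named here, the single step at this site, a 1.1-fold lower number from compound 1 to compound 2 (0.03 log units; within the scatter), did not move the read-out. Compound 3 `CCCCOC(=O)NS(=O)(=O)c1ccc(CCC)cc1-c1ccc(Cn2c(C(F)(F)F)nc3ccccc32)cc1` carries trifluoromethyl in place of propyl on an aromatic carbon. Going by the values given here, only that step bears on the change, and it was flat; the new group has no measured counterpart, so a small shift in either direction, or none beyond the scatter, is the expectation. For compound 3 the estimate is 30 nM (range 8 nM to 120 nM), corresponding to an expected step of a 2.1-fold higher number from compound 2 to compound 3 (0.33 log units; beyond the scatter).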

Compound 3, inhibition constant: 13 nM
Beside the measured number, compound 3's estimate is 2.3-fold (0.36 log units) above it, and the stated range covers the measured number.
By their numbers in this assay, from the lowest: compounds 3, 2 and 1 (each within the scatter of the next).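

In this assay, trifluoromethyl in place of propyl on the aromatic carbon between two ring nitrogen atoms gives a 1.1-fold lower number from compound 2 to compound 3 (0.03 log units; within the scatter), and trifluoromethyl in place of benzyl at the same carbon gives a 1.2-fold lower number from compound 1 to compound 3 (0.06 log units; within the scatter). The flat result now extends beyond the two carbon-only chains: across compound 1, compound 2 and compound 3, a group with three fluorine atoms stays level with propyl and benzyl, and none of the three compounds goes against this. Nothing measured here accounts for this flat result.

On these data alone, whether an amine, a carboxylic acid or a chain longer than propyl at this carbon would stay within the scatter remains open.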